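This account rests on a few compounds, and the source may have more. Where it says the series, first, only, none or still open, it means among the compounds named here.

Series notes. In a functional assay on HeLa cells (Homo sapiens) for cytotoxicity, read by cell counting, with a stated time of 48 h (a higher number here means that more compound is needed for the effect, a lower number that less compound is needed), compound 1 `CCCCCC(=O)OC[C@H]1O[C@@H](n2ccc(N)nc2=O)[C@@H](O)[C@@H]1OC(=O)CCCCC` gives 0.07 ug/mL, and compound 3 `CCCC(=O)OC[C@H]1O[C@@H](n2ccc(N)nc2=O)[C@@H](O)[C@@H]1OC(=O)CCC` gives 0.11 ug/mL. Compound 2 `CCCCCCCCCCCCCCCC(=O)O[C@H]1[C@H](O)[C@H](n2ccc(N)nc2=O)O[C@@H]1CO` gives 0.24 ug/mL in this assay, the highest of the three numbers; the nearest of the other two is compound 3 and the furthest compound 1, both gaps lying beyond the scatter. Compound 4 `CCCCCCCCCCCCCCCCCCCC(=O)O[C@H]1[C@H](O)[C@H](n2ccc(N)nc2=O)O[C@@H]1CO` has not been measured in this assay. It differs from compound 2 in one place: butyl in place of hydrogen on a saturated chain carbon, ten or more bonds along the chain from a carbonyl carbon. Among the measured compounds shown here, no measured pair shows this change, so the step can only be anticipated: a small move toward a higher number in this assay is expected, or none beyond the scatter. Compound 4 is expected to give 0.4 ug/mL, within 0.15 ug/mL to 1.2 ug/mL. The estimated step from compound 2 to compound 4 is a 1.7-fold higher number from compound 2 to compound 4 (0.22 log units; within the scatter).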

Compound 4, concentration for half-maximal effect: 0.1 ug/mL
Compound 4: middle estimate off by 4.0-fold (0.60 log units), on the high side; measured number below the stated range.
By their numbers in this assay, from the lowest: compounds 1, 4 and 3 (each within the scatter of the next); then compound 2.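

Among the compounds shown here, on a saturated chain carbon, butyl in place of hydrogen gives in this assay a 2.4-fold lower number from compound 2 to compound 4 (0.38 log units; beyond the scatter) as the first measured step of this kind. The added carbons far out on the chain therefore do not raise the number here, and the modest drop lies beyond the scatter. Nothing available explains this step.

A single pair cannot show whether a longer chain would continue this direction. On these data alone, an amine or a carboxylic acid at the chain end also remains open.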